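The source may report more compounds than this note shows. Statements on the series, on what has been measured and on what is new or still open speak of the compounds shown alone.

Measured so far in an ADME assay on LLC-MK2 cells (Macaca mulatta) for cytotoxicity, read by spectrophotometry and crystal violet staining, with a stated time of 4 days; a lower number here means that less compound is tolerated, a higher number that more compound is tolerated:
- compound 1 `CC(C)n1ncc2c(C(=O)Nc3ncccn3)cc(-c3cccs3)nc21`: 75000 nM
- compound 2 `CC(C)n1ncc2c(C(=O)Nc3cc(F)ccc3F)cc(-c3cccs3)nc21`: 100000 nM

Compound 2, at 100000 nM, cannot be separated from compound 1, as the two values lie within the scatter of each other. For the measured compounds named here, with only two measured compounds, the series offers a narrow basis for any expectation.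

Compound 3 `CC(C)n1ncc2c(C(=O)Nc3ccccn3)cc(-c3cccs3)nc21` has pyridin-2-yl in place of 2,5-difluorophenyl on an amide-type nitrogen.

Going by the values given here, one measured step bears on this change. It sits at the same place and puts 2,5-difluorophenyl in place of pyrimidin-2-yl: a 1.3-fold higher number from compound 1 to compound 2 (0.12 log units; within the scatter). Exchanging these two groups thus left the number within the scatter, and no data yet show how pyridin-2-yl behaves at this nitrogen. On that single step, no shift beyond the scatter is expected in this assay.

The expected step is a 1.2-fold lower number from compound 2 to compound 3 (0.07 log units; within the scatter).

For compound 3 the estimated value is 85000 nM, with an expected range of 45000 nM to 140000 nM.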

Compound 3, half-maximal cytotoxic concentration: > 200000 nM
Compound 3 ended at the assay's limit (the forecaster's own chance of this, stated with the estimate: 25%); at least 2.3-fold (0.37 log units) between middle value and limit.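

In this assay, compound 3 stands at a limit of the assay and not at a number: the limit of > 200000 nM in this assay, at which 1 of the 3 values shown sits. The result shows that the group on the amide-type nitrogen can matter in this assay, since the series now holds a step beyond the scatter at this place, an at least 2.6-fold higher number from compound 1 to compound 3 (0.42 log units; beyond the scatter), while the earlier exchange of pyrimidin-2-yl for 2,5-difluorophenyl stayed within it. The other new step, an at least 2.0-fold higher number from compound 2 to compound 3 (0.30 log units; that floor lies within the scatter), has a floor that lies within the scatter, so it supports no firm separation on its own, although the true gap may be larger than that floor, and the pyridin-2-yl amide is the only one of the three to reach the limit.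

Going by these compounds, how far compound 3 lies past the limit remains unknown, so neither step has a known size, and the three compounds share the rest of the core, which leaves the bearing of any other part of the structure untested here. Also open, on these data alone, is whether the same position tolerates groups of another kind, such as a pyridin-2-yl ring carrying a carboxylic acid or an amine, or a saturated ring such as piperidin-4-yl.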